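This account rests on a few compounds, and the source may have more. Where it says the series, first, only, none or still open, it means among the compounds named here.

Measured so far in a functional assay on SW480 cells (Homo sapiens) for inhibition, read by luminescence and resazurin assay, with a stated time of 3 days; on this read-out higher numbers stand for weaker inhibition and lower numbers for stronger inhibition: compound 1 `Cc1ccc(S(=O)(=O)Nc2ccc(CNc3nc(N(C)C)nc4ccccc34)cc2)cc1` gives 13000 nM; compound 2 `CN(C)c1nc(NCc2ccc(NC(=O)c3ccncc3)cc2)c2ccccc2n1` gives 11000 nM.

Compound 1 and compound 2 sit within the scatter of each other, a 1.2-fold lower number from compound 1 to compound 2 (0.07 log units; within the scatter), so neither stands apart. Compound 3 `CN(C)c1nc(NCc2ccc(C(=O)Nc3ccc(F)cc3)cc2)c2ccccc2n1` is the next member; its change from compound 2 is (4-fluorophenyl)carbamoyl in place of ((pyridin-4-yl)carbonyl)amino on an aromatic carbon. Within the data shown here, no measured step covers this exchange; the only step available, from compound 1 to compound 2, swapped the group on the same nitrogen without moving the number beyond the scatter. Compound 3 is therefore expected to stay close to compound 2, no change at the digits printed from compound 2 to compound 3 (within the scatter), with an estimated 11000 nM and a range of 4000 nM to 30000 nM.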

Compound 3, half-maximal inhibitory concentration: 2600 nM
Compound 3: middle estimate off by 4.2-fold (0.63 log units), on the high side; measured number below the stated range.
By their numbers in this assay, from the lowest: compound 3; then compounds 2 and 1 (each within the scatter of the next).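

Among these compounds, the carbon-ring carbamoyl at this place, on an aromatic carbon para to a large group, gives the first step beyond the scatter in this assay, a 4.2-fold lower number from compound 2 to compound 3 (0.63 log units; beyond the scatter). The exchange reverses the amide and replaces the pyridine ring with a fluorophenyl ring at once, so the step cannot be assigned to either change alone. Nothing available bears on the cause of this step.

Still open, going by these compounds, is whether the fluorine contributes, which a phenylcarbamoyl or a (4-methoxyphenyl)carbamoyl at this place would test. Also open, on these data alone, is how the reversed amide behaves with the pyridin-4-yl ring retained.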